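Swapping the saturated ring on the aryl ether

The source may report more compounds than this note shows. Statements on the series, on what has been measured and on what is new or still open speak of the compounds shown alone.

Compound 3 `CCS(=O)(=O)N1CC(Oc2cncc(N3C(=O)c4ccc(Cl)cc4C3(C)C)c2)C1` is the point of departure. In an assay on cells for inhibition of cytochrome P450 11B2, mitochondrial (Homo sapiens), read by HTRF (on this read-out higher numbers stand for weaker inhibition and lower numbers for stronger inhibition), compound 3 gives 4 nM. That places compound 3 level with compound 2 `CC(=O)N1CCC(Oc2cncc(N3C(=O)c4ccc(Cl)cc4C3(C)C)c2)CC1`, which gives 4 nM in this assay; together they are the two lowest numbers among the three measured. Compound 1 `CCC(=O)NCc1cncc(N2C(=O)c3ccc(Cl)cc3C2(C)C)c1` lies far away, at 282 nM in this assay.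

Compound 4 `CC(=O)N1CC[C@H](Oc2cncc(N3C(=O)c4ccc(Cl)cc4C3(C)C)c2)C1` differs from compound 3 by a group of 8 heavy atoms (6 carbon, 1 nitrogen, 1 oxygen; one five-membered non-aromatic ring with 1 hetero atom) in place of a group of 9 heavy atoms (5 carbon, 1 nitrogen, 2 oxygen, 1 sulfur; one four-membered non-aromatic ring with 1 hetero atom), on an oxygen on an aromatic ring. One measured step speaks to this kind of exchange: no change at the digits printed from compound 2 to compound 3 (within the scatter), where an acetyl-bearing six-membered ring gave way to the four-membered ring group without any shift beyond the scatter. Compound 4 carries an acetyl-bearing five-membered ring, so the exchange returns to the sort of group seen in compound 2, and because no change at the digits printed from compound 2 to compound 3 (within the scatter) showed no movement, no step beyond the scatter is expected in this assay here either. The expected step is no change at the digits printed from compound 3 to compound 4 (within the scatter), essentially flat. Compound 4 is estimated at 4 nM, with a likely range from 2 nM to 10 nM.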

Compound 4, half-maximal inhibitory concentration: 7 nM
For compound 4 the middle estimate is 1.8-fold (0.24 log units) below the measured one, within the range that was stated.
By their numbers in this assay, from the lowest: compounds 2, 3 and 4 (each within the scatter of the next); then compound 1.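

In this assay, the ring on the oxygen can also be five-membered: 1-acetylpyrrolidin-3-yl in place of 1-acetylpiperidin-4-yl gives a 1.8-fold higher number from compound 2 to compound 4 (0.24 log units; within the scatter) and leaving the group with the four-membered ring gives a 1.8-fold higher number from compound 3 to compound 4 (0.24 log units; within the scatter), so the three rings shown on this oxygen cannot be told apart. The large step remains the one at the aromatic carbon, where exchanging the ring-free group of compound 1 for the oxygen-linked five-membered ring gives a 40-fold lower number from compound 1 to compound 4 (1.61 log units; beyond the scatter). Nothing available explains why these three rings read alike.

As far as these compounds go, whether the acetyl group on the ring nitrogen matters remains open, since a free amine at that spot could read differently. So does the effect of the stereocentre in compound 4, whose opposite form is not among the compounds shown.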